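Cyano for Fluoro on Two Rings of a Shared Core

A few compounds are considered here, and "the series" means these few. Any claim that something is new, unique, unknown or untested is made for them only; others in the source may bear on it.

Of the compounds shown here, three of one series have been measured for agonist activity in a functional assay on cells for agonist activity at Free fatty acid receptor 1 (Mus musculus), read by FLIPR and calcium flux, with a stated time of 5 min; on this read-out lower numbers stand for smaller maximal responses and higher numbers for larger maximal responses. Compound 2 `Cc1nn(-c2ccccn2)c2cc(-c3ccc(CCC(=O)O)cc3F)ccc12` reaches 105%. Compound 1 `Cc1nn(-c2ccccn2)c2cc(-c3ccc(CCC(=O)O)cc3C#N)ccc12` differs from it by cyano in place of fluoro on an aromatic carbon, and compound 1 reaches 47%; the step is a number 58 percentage points lower from compound 2 to compound 1 (beyond the scatter). Compound 3 `O=C(O)CCc1ccc(-c2cc(F)c3cnn(-c4ccccn4)c3c2)cc1` carries its fluoro on the other ring; the difference between the two cores is not broken down here. In this assay compound 3 reaches 126%, the highest of the three numbers.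

Compound 4 `N#Cc1cc(-c2ccc(CCC(=O)O)cc2)cc2c1cnn2-c1ccccn1` is not yet measured. It differs from compound 3 by cyano in place of fluoro on an aromatic carbon. This is the same kind of change as that from compound 2 to compound 1, but the surroundings differ: there the place was ortho to a large group and meta to a 2-carboxyethyl group, here it is part of a fused system of two rings, ortho and meta to a fused ring and meta to a large group. Because a number 58 percentage points lower from compound 2 to compound 1 (beyond the scatter) was large, a drop is expected, though the different place makes its size uncertain; the expected step is a number 46 percentage points lower from compound 3 to compound 4 (beyond the scatter). Compound 4 is estimated at 80%, between 45% and 115%.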

Compound 4, largest response reached (reported as efficacy), in percent of the reference or control that the assay uses: 113%
For compound 4 the middle estimate is 33 percentage points below the measured one, within the range that was stated.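

In this assay, cyano in place of fluoro goes with a lower maximal response on both cores, but the two steps clearly differ in size: the same change on two cores in this assay, a number 58 percentage points lower (beyond the scatter) from compound 2 to compound 1 and a number 13 percentage points lower (beyond the scatter) from compound 3 to compound 4, 45 percentage points apart, beyond the scatter of two such steps The new step, a number 13 percentage points lower from compound 3 to compound 4 (beyond the scatter), is modest, whereas the earlier one was large, so in these two pairs the direction of the change carried over from one core to the other while its size did not. For the compounds shown here, with only two pairs, this does not show whether the gap comes from the different place of the group or from other differences between the cores, and it gives no general rule for the series.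

The compounds shown leave open how a third core would respond to the same change, and whether its step would lie nearer the modest one or the large one. They also leave open what methoxy or an amine would do at the place held by fluoro in compound 3, and how a longer chain would compare with the 2-carboxyethyl group.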